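Substituent exchange at the aromatic carbon of compound 2

The compounds below may be only part of what the source reports. "The series", "measured", "known", "first", "only" and "open" are said of these compounds alone.

Compound 1 `CS(=O)(=O)c1ccc(C(=O)N2CCC(n3cncc3-c3ccc(OS(=O)(=O)c4cccc5cnccc45)cc3)CC2)cc1` gives 25 nM in an assay on HEK293 cells for antagonist activity at P2X purinoceptor 7 (Homo sapiens), read by fluorescence, with a stated time of 2 h; on this read-out higher numbers stand for weaker inhibition and lower numbers for stronger inhibition. Compound 2 `CCN(CC)c1ccc(C(=O)N2CCC(n3cncc3-c3ccc(OS(=O)(=O)c4cccc5cnccc45)cc3)CC2)cc1` gives 1440 nM in this assay and stands highest of the two numbers. Within the data shown here, the single measured step, a 58-fold higher number from compound 1 to compound 2 (1.76 log units; beyond the scatter), is the only guide. Compound 3 `CC(C)c1ccc(C(=O)N2CCC(n3cncc3-c3ccc(OS(=O)(=O)c4cccc5cnccc45)cc3)CC2)cc1` carries isopropyl in place of diethylamino on an aromatic carbon. Among the measured compounds shown here, the measured step exchanged a group at the same aromatic carbon and moved the number far; the present change brings in a third group with no measured counterpart, so its direction is open. The expected step is a 2.4-fold lower number from compound 2 to compound 3 (0.38 log units; beyond the scatter), a moderate move downward. Compound 3 is estimated at 600 nM, within 150 nM to 2500 nM.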

Compound 3, half-maximal inhibitory concentration: 55 nM
Beside the measured number, compound 3's estimate is 11-fold (1.04 log units) above it, and the stated range ends above it.
By their numbers in this assay, from the lowest: compound 1; then compound 3; then compound 2.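

In this assay, isopropyl in place of diethylamino gives a 26-fold lower number from compound 2 to compound 3 (1.42 log units; beyond the scatter), so the high number does not extend to every group lacking the sulfonyl at this aromatic carbon. Among these compounds, the exchange of methylsulfonyl for isopropyl moves the number far less, with a 2.2-fold higher number from compound 1 to compound 3 (0.34 log units; beyond the scatter), so methylsulfonyl is not the only group here with a low number. Nothing available accounts for these differences.

On these data alone, whether the high number of compound 2 follows the nitrogen or the two ethyl chains stays open. Dimethylamino, tert-butyl or a carboxylic acid at this carbon would extend the comparison.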